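Anilide versus benzylamide at the cortical nicotinic receptor

The source may report more compounds than this note shows. Statements on the series, on what has been measured and on what is new or still open speak of the compounds shown alone.

Measured compounds:
compound 1 `O=C(Nc1ccc(F)cc1)c1cncc(N2CC3CC(C2)N3)c1` — 0.01 nM
compound 2 `COc1cccc(NC(=O)c2cncc(N3CC4CC(C3)N4)c2)c1` — 0.56 nM
compound 3 `O=C(NCc1ccccc1)c1cncc(N2CC3CC(C2)N3)c1` — 1.8 nM

In an assay on membranes from Cerebral cortex for displacement of a labelled ligand from Neuronal acetylcholine receptor; alpha4/beta2 (Rattus norvegicus) (on this read-out higher numbers stand for weaker inhibition and lower numbers for stronger inhibition), compound 3 gives the highest of the three numbers, a 3.2-fold higher number from compound 2 to compound 3 (0.51 log units; beyond the scatter) and a 180-fold higher number from compound 1 to compound 3 (2.26 log units; beyond the scatter) both setting it apart. Compound 4 `O=C(Nc1cccc(Cl)c1)c1cncc(N2CC3CC(C2)N3)c1` carries 3-chlorophenyl in place of benzyl on an amide-type nitrogen. For the measured compounds named here, two measured steps bear on this change: the replacement of a substituted phenyl by benzyl on the amide-type nitrogen gave a 180-fold higher number from compound 1 to compound 3 (2.26 log units; beyond the scatter) and a 3.2-fold higher number from compound 2 to compound 3 (0.51 log units; beyond the scatter). Reversing that direction, with a phenyl bearing a single substituent entering, is therefore expected to lower the number in this assay by a sizeable margin; the estimate for compound 4 is a 12-fold lower number from compound 3 to compound 4 (1.08 log units; beyond the scatter), and its value is expected near 0.15 nM, within the range 0.03 nM to 0.8 nM.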

Compound 4, inhibition constant: 0.042 nM
Beside the measured number, compound 4's estimate is 3.6-fold (0.55 log units) above it; the measured number falls inside the stated range.
By their numbers in this assay, from the lowest: compound 1; then compound 4; then compound 2; then compound 3.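

In this assay, compound 4 shows that the drop on replacing benzyl on the amide-type nitrogen does not depend on one particular phenyl group, with a third one giving a large step (a 43-fold lower number from compound 3 to compound 4 (1.63 log units; beyond the scatter)). The substituent on the phenyl also counts: chloro in place of methoxy gives a large step (a 13-fold lower number from compound 2 to compound 4 (1.12 log units; beyond the scatter)), and 3-chlorophenyl in place of 4-fluorophenyl a modest one (a 4.2-fold higher number from compound 1 to compound 4 (0.62 log units; beyond the scatter)). Nothing available explains these steps. The compounds shown leave open how a nitrile or a trifluoromethyl on the phenyl would compare, and how a phenethyl group on the amide-type nitrogen would stand against benzyl.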